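Swapping a Naphthalene Arm for a Chlorophenyl

The source may report more compounds than this note shows. Statements on the series, on what has been measured and on what is new or still open speak of the compounds shown alone.

Compound 1 `Cc1cc(-c2ccccc2)n(/C(N)=N/S(=O)(=O)c2cc(C)c(Cl)cc2SCc2cccc3ccccc23)n1` was tested in a functional assay on MCF7 cells (Homo sapiens) for cytotoxicity, read by MTT assay, with a stated time of 72 h (a lower number here means a stronger inhibitor, a higher number a weaker inhibitor), and gives 170000 nM, the highest of the three numbers shown, although all three lie within the usual scatter of one another. Compound 2 `Cc1cc(S(=O)(=O)/N=C(\N)n2nccc2-c2ccccc2)c(SCc2cccc(Cl)c2)cc1Cl` gives 88000 nM in this assay, and compound 3 `Cc1cc(-c2ccccc2)n(/C(N)=N/S(=O)(=O)c2cc(C)c(Cl)cc2SCc2ccc(Cl)cc2)n1` gives 108000 nM. Compound 4 `Cc1cc(-c2ccccc2)n(/C(N)=N/S(=O)(=O)c2cc(C)c(Cl)cc2SCc2ccccc2Cl)n1` differs from compound 1 by 2-chlorophenyl in place of naphthalen-1-yl on a saturated chain carbon bound to a sulfur. Going by the values given here, the one measured step that bears on this, a 1.6-fold lower number from compound 1 to compound 3 (0.20 log units; within the scatter), likewise trades the naphthalene arm for a chlorine-bearing benzene ring and stays within the scatter. A step of similar size is therefore expected for compound 4, a 1.4-fold lower number from compound 1 to compound 4 (0.15 log units; within the scatter), with no movement beyond the scatter. Compound 4 is estimated at 120000 nM, with a range from 50000 nM to 300000 nM.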

Compound 4, half-maximal inhibitory concentration: 135000 nM
Compound 4: middle estimate off by 1.1-fold (0.05 log units), on the low side, within the range that was stated.
By their numbers in this assay, from the lowest: compounds 2, 3, 4 and 1 (each within the scatter of the next).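

In this assay the 2-chlorophenyl arm, with one aromatic ring, can stand in for the two-ring naphthalen-1-yl arm without a change beyond the scatter (a 1.3-fold lower number from compound 1 to compound 4 (0.10 log units; within the scatter)). The chlorine-bearing ring also tolerates this different chlorine placement, since 2-chlorophenyl in place of 4-chlorophenyl likewise stays within the scatter (a 1.3-fold higher number from compound 3 to compound 4 (0.10 log units; within the scatter)). No measured evidence accounts for this flat picture. From the compounds shown here alone, whether an amine or a carboxylic acid at this place on the saturated chain carbon bound to a sulfur would move the number beyond the scatter remains open.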